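A few compounds are considered here, and "the series" means these few. Any claim that something is new, unique, unknown or untested is made for them only; others in the source may bear on it.

Compound 1, `Cc1cccc(C(=O)Nc2nc(-c3ccccn3)cs2)c1`, gives 4100 nM in an ADME assay on Vero cells (Chlorocebus sabaeus) for cytotoxicity, read by MTT assay, with a stated time of 72 h; a higher number here means that more compound is needed for the effect, a lower number that less compound is needed.
Compound 2, `COc1cccc(C(=O)Nc2nc(-c3ccccn3)cs2)c1`, gives 2800 nM in this assay.
Compound 3, `O=C(Nc1nc(-c2ccccn2)cs1)c1ccccc1Br`, gives 3500 nM in this assay.

These three compounds share a core and differ only in the ring attached to the carbonyl. On the numbers shown, compound 1 cannot be set apart from the other two: the step of a 1.5-fold lower number from compound 1 to compound 2 (0.17 log units; within the scatter) and the step of a 1.2-fold lower number from compound 1 to compound 3 (0.07 log units; within the scatter) both fall within the usual scatter of repeated measurements, so the three values read as essentially the same.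

Compound 4, `O=C(Nc1nc(-c2ccccn2)cs1)c1cccc(Cl)c1`, has not yet been measured. It differs from compound 1 in one place: chloro in place of methyl on an aromatic carbon.

The two measured steps that start from compound 1 are the ones that bear on this. Each of them exchanges one group for another on the ring attached to the carbonyl, and neither moved the number beyond the scatter. Nothing in the data suggests that such an exchange on that ring shifts the read-out, so compound 4 is expected to behave like the others, with no step beyond the scatter in this assay.

Compound 4 is therefore estimated at 3500 nM, within a range from 1800 nM to 7000 nM. The step this implies, a 1.2-fold lower number from compound 1 to compound 4 (0.07 log units; within the scatter), is expected to stay within the scatter.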

Compound 4, half-maximal effective concentration: 7000 nM
Compound 4: the middle estimate sits 2.0-fold (0.30 log units) below what was measured; the measured number falls inside the stated range.
By their numbers in this assay, from the lowest: compounds 2, 3, 1 and 4 (each within the scatter of the next, the first and the last beyond it).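

Chloro in place of methyl at this place on the ring, meta to a large group, gives a 1.7-fold higher number from compound 1 to compound 4 (0.23 log units; within the scatter) and so cannot be told apart from repeat-measurement noise, and the exchange of 2-bromophenyl for 3-chlorophenyl, with a 2.0-fold higher number from compound 3 to compound 4 (0.30 log units; within the scatter) as its step, stays just as unresolved. Within the data shown here, what the earlier compounds did not show is any step beyond the scatter, and chloro in place of methoxy now provides one, with a 2.5-fold higher number from compound 2 to compound 4 (0.40 log units; beyond the scatter) as a modest gap in this assay. The group at this place may therefore matter slightly for the cytotoxicity read-out, although compound 1, with its methyl, lies within the scatter of both compound 2 and compound 4, and no supporting data are available to explain the gap.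

Going by these compounds, it remains open whether this small gap would widen or vanish with a group of a different kind at the same place, such as an amine, a carboxylic acid or a longer chain. On these data alone, it is also open whether chloro would give a similar number elsewhere on this ring, or whether changes to the shared core would matter more.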